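The compounds below may be only part of what the source reports. "The series", "measured", "known", "first", "only" and "open" are said of these compounds alone.

Measured in a functional assay on HepG2 cells (Homo sapiens) for inhibition, read by MTT assay, with a stated time of 3 days; a lower number here means a stronger inhibitor, a higher number a weaker inhibitor:
- compound 1 `COc1cc(-c2nc3ccccc3s2)ccc1OCC(=O)NNC(=O)CCl`: 2890 nM
- compound 2 `COc1cc(-c2nc3ccccc3s2)ccc1OCC(=O)NNC(=O)CN1CCC[C@H]1C(=O)O`: 2650 nM

Compound 2, at 2650 nM, stands level with compound 1 within the scatter, so the two numbers give no order. Next in the series is compound 3 `CCOC(=O)CN(C)CC(=O)NNC(=O)COc1ccc(-c2nc3ccccc3s2)cc1OC`, which has ((ethoxycarbonyl)methyl)(methyl)amino in place of 2-carboxypyrrolidin-1-yl on a saturated chain carbon bound to a carbonyl carbon.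

For the measured compounds named here, one measured step bears on this change, as it falls at the same place: a 1.1-fold lower number from compound 1 to compound 2 (0.04 log units; within the scatter). Replacing chloro with 2-carboxypyrrolidin-1-yl there left the number in this assay within the scatter. Going by the values given here, that is a single step, and no measured compound carries the entering group, so the evidence for compound 3 is thin. No shift beyond the scatter is expected in either direction, and the expected change is a 1.1-fold higher number from compound 2 to compound 3 (0.02 log units; within the scatter). For compound 3 the estimate is 2800 nM, with an expected range of 1000 nM to 8000 nM.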

Compound 3, half-maximal inhibitory concentration: 3180 nM
Estimate against measurement, compound 3: 1.1-fold (0.06 log units) below, and the stated range covers the measured number.
By their numbers in this assay, from the lowest: compounds 2, 1 and 3 (each within the scatter of the next).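

In this assay, the open-chain ((ethoxycarbonyl)methyl)(methyl)amino group reads level with the ring-bearing 2-carboxypyrrolidin-1-yl group on a saturated chain carbon bound to a carbonyl carbon (a 1.2-fold higher number from compound 2 to compound 3 (0.08 log units; within the scatter)), so losing the ring, the defined stereocentre and the hydrogen-bond donor together shifts nothing beyond the scatter. The comparison with chloro at the same place gives the same reading (a 1.1-fold higher number from compound 1 to compound 3 (0.04 log units; within the scatter)), and all three groups shown there now stand within the scatter of one another, with no compound in the set going against this. Nothing measured here speaks to why the numbers stay level.

Still open, as far as these compounds go, is whether any group at this place moves the number beyond the scatter, for example a simple dimethylamino or morpholine group, a free carboxylic acid in place of the ethyl ester of compound 3, or a longer chain between the carbonyl and the nitrogen. The compounds shown also leave open whether changes to the shared core, rather than to this chain end, would separate the numbers in this assay.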